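Moving the pyridine nitrogen at the end of the chain

A few compounds are considered here, and "the series" means these few. Any claim that something is new, unique, unknown or untested is made for them only; others in the source may bear on it.

Measured compounds:
compound 1, `O=C(CCCCC#Cc1ccncc1)c1ncc(-c2ccccn2)o1`, 150 nM
compound 2, `O=C(CCCCCCc1ccccn1)c1ncc(-c2ccccn2)o1`, 120 nM

In an assay for inhibition of Fatty-acid amide hydrolase 1 (Rattus norvegicus) (a higher number here means a weaker inhibitor, a lower number a stronger inhibitor), compound 2 gives the lower of the two numbers, but the step of a 1.3-fold lower number from compound 1 to compound 2 (0.10 log units; within the scatter) is within the scatter, so the two compounds are not separated on these data. Compound 3, `O=C(CCCCCCc1cccnc1)c1ncc(-c2ccccn2)o1`, has not yet been measured. It differs from compound 2 by pyridin-3-yl in place of pyridin-2-yl on a saturated chain carbon, six bonds along the chain from a carbonyl carbon. Within the data shown here, no measured step involves exactly this change; the only measured step, a 1.3-fold lower number from compound 1 to compound 2 (0.10 log units; within the scatter), swaps one pyridine attachment for another together with the linker, and it stayed within the scatter. On that basis a change of the pyridine attachment point alone is expected to give no step beyond the scatter, so the estimated step of a 1.1-fold higher number from compound 2 to compound 3 (0.03 log units; within the scatter) is small in either direction. Compound 3 is therefore estimated at 130 nM in this assay, with a likely range from 50 nM to 350 nM.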

Compound 3, inhibition constant: 32 nM
Compound 3: the middle estimate sits 4.1-fold (0.61 log units) above what was measured; the whole stated range lies above it.
By their numbers in this assay, from the lowest: compound 3; then compounds 2 and 1 (each within the scatter of the next).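

The attachment point of the terminal pyridine matters on its own in this assay: on the unchanged saturated chain, pyridin-3-yl in place of pyridin-2-yl gives a 3.8-fold lower number from compound 2 to compound 3 (0.57 log units; beyond the scatter) and separates two compounds by more than the scatter, which the step between the earlier pair did not do. The change from 2-(pyridin-4-yl)ethynyl to 2-(pyridin-3-yl)ethyl gives a 4.7-fold lower number from compound 1 to compound 3 (0.67 log units; beyond the scatter) and makes compound 3 the strongest inhibitor of the three. Nothing at hand bears on what lies behind these steps.

As far as these compounds go, it remains open whether pyridin-4-yl on the saturated chain would stand with compound 3 or with compound 2, as compound 1 carries that ring only on the ethynyl linker. Also open, from the compounds shown here alone, is how a phenyl ring in place of the pyridine, or a longer chain, would read in this assay.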